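Amine swap from compound 3 to compound 4

This account rests on a few compounds, and the source may have more. Where it says the series, first, only, none or still open, it means among the compounds named here.

Measured values in a functional assay on SH-SY5Y cells (Homo sapiens) for antiproliferative activity, read by MTT assay, with a stated time of 72 h; a lower number here means a stronger inhibitor, a higher number a weaker inhibitor:
- compound 1 `COc1cc2c(Nc3ccc(C#N)cc3)ncnc2cc1OCCCN(C)Cc1ccccc1` gives > 100000 nM (a limit of the assay)
- compound 2 `COc1cc2c(Nc3ccc(C#N)cc3)ncnc2cc1OCCCN1CCCCC1` gives 18800 nM
- compound 3 `COc1cc2c(Nc3ccc(C#N)cc3)ncnc2cc1OCCCN1CCC(N(C)C)CC1` gives 24300 nM

Compound 3 has one numeric neighbour, which lies within the scatter, and the only further entry is a limit. Dimethylamino in place of hydrogen on a saturated ring carbon gives a 1.3-fold higher number from compound 2 to compound 3 (0.11 log units; within the scatter) and so separates these two values by no real margin.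

The next change leads to compound 4 `COc1cc2c(Nc3ccc(C#N)cc3)ncnc2cc1OCCCN1CCN(C)CC1` and puts 4-methylpiperazin-1-yl in place of 4-(dimethylamino)piperidin-1-yl on a saturated chain carbon, three bonds along the chain from an oxygen on an aromatic ring.

Two other steps alter the same place, an at least 5.3-fold lower number from compound 1 to compound 2 (0.72 log units; beyond the scatter) and an at least 4.1-fold lower number from compound 1 to compound 3 (0.61 log units; beyond the scatter), and both lie beyond the scatter. Each of them replaces benzyl(methyl)amino with a group holding a six-membered non-aromatic ring. Compound 4 keeps such a ring, so it is expected to read with compound 2 and compound 3 rather than with the limit.

The expected step, a 1.0-fold higher number from compound 3 to compound 4 (0.01 log units; within the scatter), stays within the scatter, resting on the small size of a 1.3-fold higher number from compound 2 to compound 3 (0.11 log units; within the scatter) in this series.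

The estimate for compound 4 is 25000 nM in this assay, with an expected range from 10000 nM to 70000 nM for the measurement.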

Compound 4, half-maximal inhibitory concentration: 13000 nM
For compound 4 the middle estimate is 1.9-fold (0.28 log units) above the measured one; the range from low to high includes it.
By their numbers in this assay, from the lowest: compounds 4, 2 and 3 (each within the scatter of the next). At a limit, above all of these: compound 1.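

Notes on the amine at this place, on a saturated chain carbon, three bonds along the chain from an oxygen on an aromatic ring. In this assay, a 1.9-fold lower number from compound 3 to compound 4 (0.27 log units; within the scatter) and a 1.4-fold lower number from compound 2 to compound 4 (0.16 log units; within the scatter) both stay within the scatter, so 4-methylpiperazin-1-yl cannot be told apart from either piperidine-based group. Across these three groups, one or two hetero atoms in the six-membered ring and a change from 9 to 7 heavy atoms in the group (compound 3 to compound 4) produce no readable difference. A third ring group now also separates from benzyl(methyl)amino, with an at least 7.6-fold lower number from compound 1 to compound 4 (0.88 log units; beyond the scatter), and none of the listed ring compounds goes against this, though the size of each such step remains a bound, as compound 1 is at a limit: the limit of > 100000 nM in this assay, at which 1 of the 4 values shown sits.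

Open, as far as these compounds go, is whether the benzyl group or the open-chain amine sets compound 1 apart, a question that 4-benzylpiperazin-1-yl or plain dimethylamino on the same chain would address. Also open, from the compounds shown here alone, is whether the flat reading among ring groups extends to morpholin-4-yl or to a shorter or longer chain carrying 4-methylpiperazin-1-yl.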